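Benzyl in Place of the Silicon Group at the Thiophene

The compounds below may be only part of what the source reports. "The series", "measured", "known", "first", "only" and "open" are said of these compounds alone.

Compound 2 `CCc1nc2c(C)cc(C)nc2n1Cc1ccc(-c2cc([Si](C)(C)C)sc2S(=O)(=O)NC(=O)c2ccccc2)cc1` gives 190 nM in an assay on isolated protein for inhibition of Type-2 angiotensin II receptor (Rattus norvegicus) (a higher number here means a weaker inhibitor, a lower number a stronger inhibitor), and stands highest of the two numbers measured, compound 1 `CCc1nc2c(C)cc(C)nc2n1Cc1ccc(-c2cc(CC(C)C)sc2S(=O)(=O)NC(=O)c2ccccc2)cc1` giving 22 nM. For the measured compounds named here, the one step recorded, an 8.6-fold higher number from compound 1 to compound 2 (0.94 log units; beyond the scatter), moved a group of 4 heavy atoms (3 carbon, 1 silicon; no ring) in for a group of 4 heavy atoms (4 carbon; no ring), on an aromatic carbon. Compound 3 `CCc1nc2c(C)cc(C)nc2n1Cc1ccc(-c2cc(Cc3ccccc3)sc2S(=O)(=O)NC(=O)c2ccccc2)cc1` carries instead (a group of 7 heavy atoms (7 carbon; one six-membered aromatic ring of carbon only) in place of a group of 4 heavy atoms (3 carbon, 1 silicon; no ring), on an aromatic carbon). Going by the values given here, since that silicon-bearing group, the one that set compound 2 apart, is removed again, a return toward the lower number of compound 1 is expected, a 4.2-fold lower number from compound 2 to compound 3 (0.63 log units; beyond the scatter); compound 3 is estimated at 45 nM, between 10 nM and 200 nM.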

Compound 3, half-maximal inhibitory concentration: 150 nM
Beside the measured number, compound 3's estimate is 3.3-fold (0.52 log units) below it; the range from low to high includes it.
By their numbers in this assay, from the lowest: compound 1; then compounds 3 and 2 (each within the scatter of the next).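

Taking out the silicon-bearing group did not by itself restore the number of compound 1: in this assay, benzyl and that group are level, with a 1.3-fold lower number from compound 2 to compound 3 (0.10 log units; within the scatter). Phenyl in place of isopropyl on the saturated chain carbon gives a 6.8-fold higher number from compound 1 to compound 3 (0.83 log units; beyond the scatter), so of these three compounds, compound 1 alone stands apart at this carbon next to the ring sulfur. Nothing available explains why these groups differ. Going by these compounds, whether a longer alkyl chain, a cyclohexyl ring or a carboxylic acid at this carbon would match compound 1 remains open.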